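A Second Chloro on a Different Core

A few compounds are considered here, and "the series" means these few. Any claim that something is new, unique, unknown or untested is made for them only; others in the source may bear on it.

Compound 1 `Cn1c(=O)[nH]c2ccc(OCc3ccc(Cl)cc3)cc21` gives 56400 nM in an assay on cells for inhibition of Amine oxidase [flavin-containing] B (Homo sapiens), read by fluorescence, with stated times of 30 min and 15 min; on this read-out lower numbers stand for stronger inhibition and higher numbers for weaker inhibition. Compound 2 `Cn1c(=O)[nH]c2ccc(OCc3ccc(Cl)c(Cl)c3)cc21` gives 7680 nM in this assay. Compound 3 `CC1(C)C(=O)Nc2ccc(OCc3cccc(Cl)c3)cc21` gives 279000 nM in this assay.

Compound 1 and compound 2 differ by chloro in place of hydrogen on an aromatic carbon, a change that made a 7.3-fold lower number from compound 1 to compound 2 (0.87 log units; beyond the scatter). Compound 3 and compound 4 `CC1(C)C(=O)Nc2ccc(OCc3ccc(Cl)c(Cl)c3)cc21` differ by the same kind of change, (chloro in place of hydrogen on an aromatic carbon); the entering chloro sits ortho to a chloro group and para to a large group, whereas in compound 2 it sits ortho to a chloro group and meta to a large group. The difference between the two cores is not broken down here. Because the step of a 7.3-fold lower number from compound 1 to compound 2 (0.87 log units; beyond the scatter) was modest, a step of similar size is expected for compound 4, giving a 5.1-fold lower number from compound 3 to compound 4 (0.71 log units; beyond the scatter). Compound 4 is therefore estimated at 55000 nM, between 20000 nM and 150000 nM.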

Compound 4, half-maximal inhibitory concentration: 132000 nM
Beside the measured number, compound 4's estimate is 2.4-fold (0.38 log units) below it; the range from low to high includes it.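

On the core of compound 3, the added chloro again lowers the number (a 2.1-fold lower number from compound 3 to compound 4 (0.33 log units; beyond the scatter)), so the direction of the change carries over from one core to the other in this assay. Its size does not carry over: the same change on two cores in this assay, a 7.3-fold lower number (0.87 log units; beyond the scatter) from compound 1 to compound 2 and a 2.1-fold lower number (0.33 log units; beyond the scatter) from compound 3 to compound 4, 3.5-fold (0.54 log units) apart, beyond the scatter of two such steps. This does not show why the steps differ, since the two pairs differ both in their core and in where the entering chloro sits on the ring, and these compounds cannot separate those two differences.

Going by these compounds, it remains open how the core of compound 3 would respond to a single chloro placed as in compound 1. On these data alone, it also remains open whether a fluoro or methoxy group entering in place of the chloro would follow the same direction on both cores.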